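Chloro in Place of Hydrogen on an Amide-Linked Ring

The source may hold more compounds than are shown below. What is called first, only, known or untested is meant among the compounds shown, and "the series" means these compounds.

Measured so far:
- compound 1, `O=C(Nc1ccccc1)c1cccc2oc(=O)[nH]c12` — 2200 nM
- compound 2, `COc1cccc(NC(=O)c2cccc3oc(=O)[nH]c23)c1` — 3900 nM

Both compounds share one core and differ only on the ring attached through the amide. In an assay on isolated protein for binding affinity to metabotropic glutamate receptor 5 (Homo sapiens) (a lower number here means a stronger inhibitor, a higher number a weaker inhibitor), compound 1 gives 2200 nM, the lower of the two numbers, but the gap to compound 2 is small: a 1.8-fold higher number from compound 1 to compound 2 (0.25 log units; within the scatter), which the scatter of repeated measurements covers. On these two values, then, nothing separates compound 1 from compound 2 beyond noise.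

Compound 3, `O=C(Nc1ccc(Cl)cc1)c1cccc2oc(=O)[nH]c12`, has not been measured. Its change from compound 1 is chloro in place of hydrogen on an aromatic carbon, with the chlorine standing para to a large group. Within the data shown here, no measured step probes a chloro substituent, so the only guide is the one step available, from compound 1 to compound 2, which placed a methoxy group on the same ring and stayed within the scatter. A single small substituent on that ring therefore seems to move the number little, if at all.

The expectation for compound 3 is accordingly no step beyond the scatter: a 1.1-fold lower number from compound 1 to compound 3 (0.04 log units; within the scatter). The estimated value for compound 3 in this assay is 2000 nM, with a range from 700 nM to 6000 nM.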

Compound 3, inhibition constant: 3800 nM
For compound 3 the middle estimate is 1.9-fold (0.28 log units) below the measured one, and the stated range covers the measured number.
By their numbers in this assay, from the lowest: compounds 1, 3 and 2 (each within the scatter of the next).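

In this assay, chloro in place of hydrogen on an aromatic carbon, para to a large group, gives a 1.7-fold higher number from compound 1 to compound 3 (0.24 log units; within the scatter) and so cannot be told apart from compound 1 at this position. Set beside a 1.8-fold higher number from compound 1 to compound 2 (0.25 log units; within the scatter) and its methoxy group, this means the earlier reading of the amide-linked ring no longer rests on a single kind of substituent: a chloro and a methoxy have each left the number within the scatter of compound 1. No measurement is available that could explain this result, so its cause stays unknown.

Among these compounds, still open is whether any group on this ring can move the number beyond the scatter, since both steps so far add only one small substituent, and an amine, a carboxylic acid or a longer chain could give a very different result. The shared core and the amide link are also the same in all three compounds, so these values say nothing about how much either part matters in this assay for the number.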